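The compounds below may be only part of what the source reports. "The series", "measured", "known", "first", "only" and "open" are said of these compounds alone.

Measured compounds, read in an assay on Sf9 cells for inhibition of 1-acyl-sn-glycerol-3-phosphate acyltransferase beta (Homo sapiens); on this read-out lower numbers stand for stronger inhibition and higher numbers for weaker inhibition:

- compound 1 `Nc1nc(Nc2ccc(Cl)cc2)cc(-c2ccccc2)n1`: 1100 nM
- compound 2 `Nc1nc(Nc2ccc(Cl)cc2)cc(-c2cc(Cl)ccc2Cl)n1`: 20 nM
- compound 3 `Cc1ccc(Cl)cc1-c1cc(Nc2ccc(Br)cc2)nc(N)n1`: 34 nM

Compound 3 holds the second highest of the three numbers in this assay. Its nearest neighbour is compound 2, whose number is lower by a margin that lies within the usual scatter, so the two cannot be ordered against each other. Its furthest neighbour is compound 1, whose number is far higher, a gap well beyond the scatter. Among the measured compounds shown here, no pair of measured compounds differs in a single place, so no measured step can be read from the set.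

Compound 4 `Cc1ccc(Cl)cc1-c1cc(Nc2cccc(Br)c2)nc(N)n1` is not yet measured. Against compound 3 it carries 3-bromophenyl in place of 4-bromophenyl on a nitrogen on an aromatic ring; the two compounds hold the same atoms, joined differently. With no measured step of this kind in the set, the expectation rests on the structural change alone: a modest move toward a higher number, or no step beyond the scatter, is expected. For compound 4 the estimate in this assay is 60 nM, with a range from 15 nM to 250 nM; the expected step is a 1.8-fold higher number from compound 3 to compound 4 (0.25 log units; within the scatter).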

Compound 4, half-maximal inhibitory concentration: 610 nM
Beside the measured number, compound 4's estimate is 10-fold (1.01 log units) below it; the measured number lies above the stated range.
By their numbers in this assay, from the lowest: compounds 2 and 3 (each within the scatter of the next); then compounds 4 and 1 (each within the scatter of the next).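

In this assay, 3-bromophenyl in place of 4-bromophenyl on a nitrogen on an aromatic ring gives an 18-fold higher number from compound 3 to compound 4 (1.25 log units; beyond the scatter), so this position distinguishes between two groups that have identical atom counts. The two compounds hold the same atoms, joined differently. The earlier compounds could not have shown this: in this pair the step comes from the arrangement alone, not from any gain or loss of atoms, and the read-out is clearly sensitive to where the bromine sits on this ring. No measurement at hand bears on why this rearrangement gives a step of this size.

Going by these compounds, it remains open whether the step is particular to bromine or would recur with other groups on this ring, such as a methoxy group, a nitrile or an amine, at either of the two sites. On these data alone, it also remains open whether the same change would give a step of similar size with the other aromatic groups that compound 1 and compound 2 carry on the shared core.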